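From methoxy to propyl: what the numbers suggest

The source may report more compounds than this note shows. Statements on the series, on what has been measured and on what is new or still open speak of the compounds shown alone.

Values in a functional assay on MGC-803 cells (Homo sapiens) for antiproliferative activity, read by CCK-8 assay, with a stated time of 72 h; a higher number here means a weaker inhibitor, a lower number a stronger inhibitor:
- Compound 1 `Nc1ccccc1NC(=O)c1ccc(COc2ccc([N+](=O)[O-])cc2)cc1`: > 32000 nM, a limit of the assay
- Compound 2 `Nc1ccccc1NC(=O)c1ccc(COc2ccc(Br)cc2)cc1`: > 32000 nM, a limit of the assay
- Compound 3 `COc1ccc(OCc2ccc(C(=O)Nc3ccccc3N)cc2)cc1`: 3480 nM

Compound 3 alone has a true number. The other two compounds sit at the limit of > 32000 nM in this assay, at which 2 of the 3 values shown sit. Compound 4 `CCCc1ccc(OCc2ccc(C(=O)Nc3ccccc3N)cc2)cc1` carries propyl in place of methoxy on an aromatic carbon. For the measured compounds named here, two measured steps bear on this change, an at least 9.1-fold lower number from compound 1 to compound 3 (0.96 log units; beyond the scatter) and an at least 9.1-fold lower number from compound 2 to compound 3 (0.96 log units; beyond the scatter). Both show that the group at this carbon can matter, but neither involves propyl, so they give no firm direction. The estimated step is a 1.7-fold higher number from compound 3 to compound 4 (0.24 log units; within the scatter), so no step beyond the scatter is expected, although a clear loss remains possible. For compound 4 the expected value is 6000 nM, with an estimated range of 1500 nM to 25000 nM.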

Compound 4, half-maximal inhibitory concentration: 4420 nM
The estimate for compound 4 lay 1.4-fold (0.13 log units) above the measured number; the measured number falls inside the stated range.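

In this assay, propyl at this carbon does as well as methoxy (a 1.3-fold higher number from compound 3 to compound 4 (0.10 log units; within the scatter)), so the oxygen of methoxy is not needed to keep a measurable value here. Propyl also keeps the gain over bromo (an at least 7.2-fold lower number from compound 2 to compound 4 (0.85 log units; beyond the scatter)) and over nitro (an at least 7.2-fold lower number from compound 1 to compound 4 (0.85 log units; beyond the scatter)). Compound 1 and compound 2 each stand at a limit of the assay, so these two steps give only a minimum size: the limit of > 32000 nM in this assay, at which 2 of the 4 values shown sit.

On these data alone, whether a longer chain such as butyl, or an amine, at this carbon would hold this level remains open. With only methoxy and propyl giving true numbers, no trend with chain length can be read.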